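Notes on Nitrogen Substitution in the Shared Core

A few compounds are considered here, and "the series" means these few. Any claim that something is new, unique, unknown or untested is made for them only; others in the source may bear on it.

The series rests on one shared core, read in a functional assay on A-375 cells (Homo sapiens) for antiproliferative activity, read by MTT assay, with a stated time of 72 h; on this read-out higher numbers stand for weaker inhibition and lower numbers for stronger inhibition. Compound 1 `COc1ncc(-c2ccc3c(c2)NC(=O)CO3)cc1NS(=O)(=O)c1ccc(F)cc1` carries hydrogen on the amide-type nitrogen in the ring; in this assay compound 1 gives 26300 nM. Compound 2 `COc1ncc(-c2ccc3c(c2)N(C(C)C)C(=O)CO3)cc1NS(=O)(=O)c1ccc(F)cc1` carries isopropyl at the same place; in this assay compound 2 gives 9950 nM. The step of a 2.6-fold lower number from compound 1 to compound 2 (0.42 log units; beyond the scatter) is the only one measured so far, and on it compound 2 stands lowest of the two numbers, with compound 1 the nearest and only other point.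

Compound 3 `COc1cccc(N2C(=O)COc3ccc(-c4cnc(OC)c(NS(=O)(=O)c5ccc(F)cc5)c4)cc32)c1` is not yet measured. Its difference from compound 2: 3-methoxyphenyl in place of isopropyl on an amide-type nitrogen in a ring. Among the compounds with values here, the one measured step bears on it only in that it also changes what sits on the amide-type nitrogen in the ring; that step was modest, beyond the scatter, toward a lower number. Nothing measured tells how 3-methoxyphenyl compares with isopropyl at that place. On that basis the expected step is a 1.4-fold lower number from compound 2 to compound 3 (0.15 log units; within the scatter), near the scatter and leaning lower. Compound 3 is estimated at 7000 nM, with a range from 2000 nM to 25000 nM.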

Compound 3, half-maximal inhibitory concentration: > 40000 nM
Compound 3 gave a limit, no number; the forecaster's own chance of this, stated with the estimate: 5%; middle value at least 5.7-fold (0.75 log units) from the limit.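

In this assay compound 3 gives only a limit of the assay and not a number: the limit of > 40000 nM in this assay, at which 1 of the 3 values shown sits.

The amide-type nitrogen in the ring therefore does not answer in one direction as the group on it grows: isopropyl gave a 2.6-fold lower number from compound 1 to compound 2 (0.42 log units; beyond the scatter), whereas 3-methoxyphenyl, with its six-membered aromatic ring, gives an at least 4.0-fold higher number from compound 2 to compound 3 (0.60 log units; beyond the scatter). Within the data shown here, measured against hydrogen at the same place, the change gives an at least 1.5-fold higher number from compound 1 to compound 3 (0.18 log units; that floor lies within the scatter), so of the two steps into 3-methoxyphenyl, only the one from isopropyl can be read as beyond the scatter.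

On these data alone, the true size of both steps into 3-methoxyphenyl stays open, as each has a limit at one end. Also open, as far as these compounds go, is whether the rise in the number goes with the aromatic ring itself or with its methoxy group, and how plain phenyl, benzyl, ethyl, a longer chain or a chain ending in an amine would read on this nitrogen.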